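This account rests on a few compounds, and the source may have more. Where it says the series, first, only, none or still open, it means among the compounds named here.

In a functional assay on HEK293 cells for agonist activity at G-protein coupled receptor 39 (Homo sapiens), read by scintillation proximity assay and inositol phosphate accumulation, with a stated time of 75 min (on this read-out higher numbers stand for an effect only at larger amounts of compound and lower numbers for an effect already at smaller amounts), compound 2 `Cc1nn(-c2ncnc3nc[nH]c23)c2c1C(OC1CCCC1)CC(=O)N2` gives 62 nM, the lowest of the three numbers seen so far. Compound 1 `Cc1nn(-c2ncnc3nc[nH]c23)c2c1C(OCC(=O)c1ccc(F)cc1)CC(=O)N2` gives 973 nM, and compound 3 `Cc1nn(-c2ncnc3nc[nH]c23)c2c1C(OCc1ccc(C(C)C)cc1)CC(=O)N2` gives 1690 nM. The step under consideration leads to compound 4 `Cc1nn(-c2ncnc3nc[nH]c23)c2c1C(OCc1ccccc1Cl)CC(=O)N2`, which differs from compound 2 by 2-chlorobenzyl in place of cyclopentyl on an oxygen on a saturated carbon. Within the data shown here, two measured steps bear on this change: a 27-fold higher number from compound 2 to compound 3 (1.44 log units; beyond the scatter) and a 16-fold lower number from compound 1 to compound 2 (1.20 log units; beyond the scatter). In both of these the cyclopentyl compound gives the lower number, so a move to a higher number is expected for compound 4, though perhaps a smaller one than that seen for compound 3. Compound 4 is therefore estimated to give 600 nM, with a range from 150 nM to 2500 nM. That would be an expected step of a 9.7-fold higher number from compound 2 to compound 4 (0.99 log units; beyond the scatter).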

Compound 4, half-maximal effective concentration: 47 nM
The estimate for compound 4 lay 13-fold (1.11 log units) above the measured number; the measured number lies below the stated range.
By their numbers in this assay, from the lowest: compounds 4 and 2 (each within the scatter of the next); then compounds 1 and 3 (each within the scatter of the next).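

In this assay, 2-chlorobenzyl in place of cyclopentyl on this oxygen gives a 1.3-fold lower number from compound 2 to compound 4 (0.12 log units; within the scatter) and so shows that a six-membered aromatic ring here can go with a number as low as that of the cyclopentyl compound. The group on the saturated chain carbon makes a large difference, with a 36-fold lower number from compound 3 to compound 4 (1.56 log units; beyond the scatter) and a 21-fold lower number from compound 1 to compound 4 (1.32 log units; beyond the scatter) for the change to 2-chlorophenyl. Nothing available explains these differences.

On these data alone, whether plain benzyl would match 2-chlorobenzyl remains open. So does the effect of an amine or a carboxylic acid on that ring.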